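From hydroxy to methoxy on compound 1

The compounds below may be only part of what the source reports. "The series", "measured", "known", "first", "only" and "open" are said of these compounds alone.

compound 1 `O=C(NCCCNc1cc(-c2cn(-c3ccccc3)nc2-c2cccc(O)c2)ccn1)Nc1ccc(F)cc1`: 19300 nM
compound 2 `O=C(NCCCNc1cc(-c2cn(-c3ccccc3)nc2-c2cccc(O)c2)ccn1)Nc1cccc(C(F)(F)F)c1`: 11900 nM
compound 3 `COc1cccc(-c2nn(-c3ccccc3)cc2-c2ccnc(NCCCNC(=O)Nc3ccc(F)cc3)c2)c1`: not yet measured

In a functional assay on DU-145 cells (Homo sapiens) for antiproliferative activity, read by sulforhodamine B assay, with a stated time of 48 h (on this read-out lower numbers stand for stronger inhibition of growth and higher numbers for weaker inhibition of growth), compound 1 gives 19300 nM and compound 2 gives 11900 nM, so the two cannot be told apart. Compound 3 differs from compound 1 by methyl in place of hydrogen on an oxygen on an aromatic ring, turning hydroxy into methoxy. Going by the values given here, the only measured step, a 1.6-fold lower number from compound 1 to compound 2 (0.21 log units; within the scatter), lies elsewhere in the molecule, and no measured step touches this oxygen. In this assay no step beyond the scatter is therefore expected, and no direction can be favoured. The estimated step is a 1.1-fold lower number from compound 1 to compound 3 (0.06 log units; within the scatter). For compound 3 the expected value is 17000 nM, with an estimated range from 7000 nM to 40000 nM.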

Compound 3, concentration for total growth inhibition: > 37000 nM
Compound 3 ended at the assay's limit; the forecaster's own chance of this, stated with the estimate: 10%; middle value at least 2.1-fold (0.33 log units) from the limit.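

This is the first change at this oxygen, and in this assay compound 3, with its 3-methoxyphenyl, gives a limit of the assay and not a number: the limit of > 37000 nM in this assay, at which 1 of the 3 values shown sits.

The step, an at least 1.9-fold higher number from compound 1 to compound 3 (0.28 log units; that floor lies within the scatter) and so only a floor, shows that methyl in place of hydrogen here gave no stronger inhibition of growth, while any true loss stays hidden behind the limit.

As far as these compounds go, whether a longer chain on this oxygen, or an amine in place of the hydroxy, would keep growth inhibition remains open. So does whether methoxy acts the same alongside the 3-(trifluoromethyl)phenyl of compound 2.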